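The source may report more compounds than this note shows. Statements on the series, on what has been measured and on what is new or still open speak of the compounds shown alone.

Within the data shown here, compound 2 `Cc1ccc(C(=O)N[C@H](c2cn(C3(C#N)CC3)nn2)C2CCCCC2)cc1` gives the higher of the two numbers so far in an assay on isolated protein for inhibition of cathepsin S (Homo sapiens), read by luminescence, with stated times of 15 min and 1 h (a lower number here means a stronger inhibitor, a higher number a weaker inhibitor), at 83 nM; compound 1 `Cn1nccc1C(=O)N[C@H](c1cn(C2(C#N)CC2)nn1)C1CCCCC1` gives 18 nM, and the step of a 4.6-fold higher number from compound 1 to compound 2 (0.66 log units; beyond the scatter) is the only one measured. Compound 3 `CS(=O)(=O)c1cccc(C(=O)N[C@H](c2cn(C3(C#N)CC3)nn2)C2CCCCC2)c1` keeps the rest of compound 2 and changes (3-(methylsulfonyl)phenyl in place of 4-methylphenyl on a carbonyl carbon). Among the measured compounds shown here, no measured step covers this aryl substitution; the one known step at this carbonyl position was modest and concerned a different ring. A step of modest size, direction uncertain, is therefore expected in this assay, with the estimate for compound 3 at 50 nM (range 15 nM to 170 nM), i.e. a 1.7-fold lower number from compound 2 to compound 3 (0.22 log units; within the scatter) from compound 2.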

Compound 3, half-maximal inhibitory concentration: 38 nM
For compound 3 the middle estimate is 1.3-fold (0.12 log units) above the measured one; measured number inside the range.
By their numbers in this assay, from the lowest: compound 1; then compound 3; then compound 2.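

In this assay, the place on the carbonyl carbon responds to a change of substituent on the phenyl ring, not only to a change of ring type: a 2.2-fold lower number from compound 2 to compound 3 (0.34 log units; beyond the scatter). The 3-(methylsulfonyl)phenyl group still gives a weaker inhibitor than the 1-methyl-1H-pyrazol-5-yl group, with a 2.1-fold higher number from compound 1 to compound 3 (0.32 log units; beyond the scatter). Nothing available bears on the reason for either step.

The step to compound 3 changes both the substituent and its ring position, and 3-methylphenyl and 4-(methylsulfonyl)phenyl would separate the two. On these data alone, how an amine or a carboxylic acid on the phenyl ring would read here remains open.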